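The source may hold more compounds than are shown below. What is called first, only, known or untested is meant among the compounds shown, and "the series" means these compounds.

Measured so far:
compound 1 `CN(C)Cc1ccc2nc(NC(=O)N/N=C3\C(=O)Nc4ccc(F)cc43)sc2c1` — no number in a functional assay on MDA-MB-231 cells (Homo sapiens) for cytotoxicity, read by MTT assay, with a stated time of 72 h (a lower number here means a stronger inhibitor, a higher number a weaker inhibitor), recorded as "not determined" (no result reported)
compound 2 `CC1CCN(Cc2ccc3nc(NC(=O)N/N=C/c4cn(Cc5ccc(Cl)cc5Cl)c5ccccc45)sc3c2)CC1` — this assay: 3140 nM
compound 3 `CCN(CC)Cc1ccc2nc(NC(=O)N/N=C/c3c[nH]c4ccccc34)sc2c1` — this assay: 1900 nM

Compound 3 has the lower of the two numbers reported, but its nearest neighbour, compound 2, sits within the usual scatter of it, so the two cannot be ordered on these data. Compound 1 brings no number to the comparison.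

The step under consideration leads to compound 4 `CCN(CC)Cc1ccc2nc(NC(=O)N/N=C/c3cn(Cc4ccc(C)cc4)c4ccccc34)sc2c1`. Against compound 3 the change is 4-methylbenzyl in place of hydrogen on an aromatic nitrogen. For the measured compounds named here, no step between measured compounds has been recorded for this kind of change. Compound 2 carries a different benzyl group on the same kind of aromatic nitrogen, with a different amine elsewhere, and its value stays within the scatter of compound 3, which gives no sign that a group on this nitrogen moves the number much either way.

The expectation for compound 4 is therefore a step from compound 3 of a 1.3-fold higher number from compound 3 to compound 4 (0.12 log units; within the scatter), not beyond the scatter. Compound 4 is estimated at 2500 nM, with a range of 1000 nM to 6000 nM.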

Compound 4, half-maximal inhibitory concentration: 2010 nM
Compound 4: middle estimate off by 1.2-fold (0.09 log units), on the high side, within the range that was stated.
By their numbers in this assay, from the lowest: compounds 3, 4 and 2 (each within the scatter of the next).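

For the compounds shown here, the first direct step on this aromatic nitrogen, in this assay, is a 1.1-fold higher number from compound 3 to compound 4 (0.02 log units; within the scatter) and lies within the scatter. Placing 4-methylbenzyl here in place of hydrogen, with the diethylamino end of the molecule held constant, therefore leaves the two numbers indistinguishable. The free hydrogen on this nitrogen is thus not needed to keep the number in this assay, and a group bearing one six-membered aromatic ring of carbon only is accommodated at this position, at least for this single pair.

Open, going by these compounds, is whether a group of another kind on this nitrogen, such as a carboxylic acid or a chain ending in an amine, would give a step beyond the scatter. No supporting measurement is available that would speak to what lies behind this result.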